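The source may report more compounds than this note shows. Statements on the series, on what has been measured and on what is new or still open speak of the compounds shown alone.

Of the compounds shown here, two have been measured in a functional assay on CHO-K1 cells with Glucose-dependent insulinotropic receptor (Homo sapiens) as the target, read by a luciferase reporter, with a stated time of 5 h (a lower number here means a smaller maximal response, a higher number a larger maximal response), and a third awaits testing. Compound 1 `CC(C)OC(=O)N1CCC(Oc2cccc3c2CCN3c2ccc(S(C)(=O)=O)cc2F)CC1` gives 62% in this assay. Compound 2 `CCCCOC(=O)N1CCC(Oc2ncnc3c2CCN3c2ccc(S(C)(=O)=O)cc2F)CC1` gives 131% in this assay, the higher of the two numbers; the gap to compound 1 lies beyond the usual scatter. Compound 1 and compound 2 differ in more than one place, so no single step can be read from them.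

Compound 3 `CC(C)c1noc(N2CCC(Oc3ncnc4c3CCN4c3ccc(S(C)(=O)=O)cc3F)CC2)n1` is built from compound 2 by one change: 3-isopropyl-1,2,4-oxadiazol-5-yl in place of butoxycarbonyl on an amine nitrogen in a ring. Going by the values given here, no measured pair shows the effect of this exchange, so its size is open. The expected step from compound 2 to compound 3, a number 16 percentage points lower from compound 2 to compound 3 (beyond the scatter), is small, downward, and within the scatter. Compound 3 is therefore estimated to give 115% in this assay, with a range from 70% to 150%.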

Compound 3, largest response reached (reported as percent of maximum), in percent of the reference or control that the assay uses: 124%
Compound 3: the middle estimate sits 9 percentage points below what was measured; measured number inside the range.
By their numbers in this assay, from the lowest: compound 1; then compounds 3 and 2 (each within the scatter of the next).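

At this position, on an amine nitrogen in a ring, replacing butoxycarbonyl with 3-isopropyl-1,2,4-oxadiazol-5-yl gives a number 7 percentage points lower from compound 2 to compound 3 (within the scatter) in this assay and so leaves the maximal response unchanged within the usual scatter. Going by these compounds alone, this is the first change in the set that can be read on its own, and it shows that a group with no ring can give way to one with a five-membered aromatic ring while the response stays at the same level. No measurement on hand explains this result.

As far as these compounds go, whether a simple acetyl group, a phenyl ring or a longer chain on the same nitrogen would also hold the response remains open. The steps from compound 1 to compound 2 and to compound 3 cannot be read, as those compounds differ in more than one place.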